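A Second Methoxy Group on Compound 2

The compounds below may be only part of what the source reports. "The series", "measured", "known", "first", "only" and "open" are said of these compounds alone.

Of the compounds shown here, three sharing one core have been measured so far in a functional assay on FM3A cells (Mus musculus) for antiproliferative activity, with a stated time of 48 h; on this read-out higher numbers stand for weaker inhibition and lower numbers for stronger inhibition. Compound 1 `C=C(Br)C(=O)Nc1ccc(C(=O)/C=C/c2ccc(OC)cc2)cc1` gives 1000 nM, compound 2 `C=C(Br)C(=O)Nc1ccc(C(=O)/C=C/c2cccc(OC)c2)cc1` gives 1800 nM, and compound 3 `C=C(Br)C(=O)Nc1ccc(C(=O)/C=C/c2ccc(OC)c(OC)c2)cc1` gives 1200 nM. Compound 2 lies within the usual scatter of both others, so these numbers set no order among the three.

Compound 4 `C=C(Br)C(=O)Nc1ccc(C(=O)/C=C/c2cc(OC)cc(OC)c2)cc1` differs from compound 2 in one place: methoxy in place of hydrogen on an aromatic carbon. This is methoxy in place of hydrogen on an aromatic carbon, meta to a methoxy group.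

The closest evidence is the same kind of change made on a different aromatic carbon of compound 2, which gave a 1.5-fold lower number from compound 2 to compound 3 (0.18 log units; within the scatter). The same kind of change on compound 1 gave a 1.2-fold higher number from compound 1 to compound 3 (0.08 log units; within the scatter). Shifting the single methoxy group gave a 1.8-fold higher number from compound 1 to compound 2 (0.26 log units; within the scatter). None of these steps leaves the scatter, so no step beyond the scatter is expected in this assay, and no direction can be favoured with any confidence. Going by the values given here, no measured compound has its two methoxy groups arranged this way, so the range is kept wide.

The expected step is a 1.3-fold lower number from compound 2 to compound 4 (0.11 log units; within the scatter). For compound 4 the estimated value is 1400 nM, with an expected range from 700 nM to 2800 nM.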

Compound 4, half-maximal inhibitory concentration: 2000 nM
For compound 4 the middle estimate is 1.4-fold (0.15 log units) below the measured one, within the range that was stated.
By their numbers in this assay, from the lowest: compounds 1, 3, 2 and 4 (each within the scatter of the next).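

In this assay, placing a second methoxy group on this aromatic carbon, meta to a methoxy group, gives a 1.1-fold higher number from compound 2 to compound 4 (0.05 log units; within the scatter), so compound 4 cannot be told apart from compound 2. Going by these compounds alone, until now, a second methoxy group had been read at only one arrangement, the one in compound 3, so compound 4 shows that a second arrangement also stays within the scatter. The change also reads much the same on two different starting compounds, which suggests that among these four compounds the effect of adding this group does not depend on where the first methoxy group sits: the same change on two cores in this assay, a 1.2-fold higher number (0.08 log units; within the scatter) from compound 1 to compound 3 and a 1.1-fold higher number (0.05 log units; within the scatter) from compound 2 to compound 4, 1.1-fold (0.03 log units) apart, within the scatter of two such steps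

Going by these compounds, all four compounds carry only methoxy groups on this ring, so it remains open whether a different group on the same carbon, such as an amine, a carboxylic acid or a longer alkoxy chain, would move the number beyond the scatter. Within the data shown here, with every step so far inside the scatter, these compounds also cannot show whether the position of a substituent on this ring matters at all in this cell assay.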